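Chloro for trifluoromethyl on the urea aryl ring

The compounds below may be only part of what the source reports. "The series", "measured", "known", "first", "only" and "open" are said of these compounds alone.

Measured compounds:
compound 1, `O=C(Nc1cccc(-n2cc(-c3ccncc3)c(-c3cc(O)cc(Cl)c3)n2)c1)Nc1ccc(Cl)c(Cl)c1`, 102%;
compound 2, `COc1cc(Cl)cc(-c2nn(-c3cccc(NC(=O)Nc4ccc(Cl)c(C(F)(F)F)c4)c3)cc2-c2ccncc2)c1`, 100%.

In a functional assay on NCI-H460 cells (Homo sapiens) for inhibition, read by sulforhodamine B assay, with a stated time of 48 h, tested at 0.01 uM (a higher number here means a weaker effect of the compound at the concentration tested, a lower number a stronger effect), compound 2 gives 100%. In this assay compound 1 gives 102%, and the two numbers lie within the scatter of each other, so neither compound can be said to act more strongly at this concentration; both read as essentially no effect.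

Compound 3, `COc1cc(Cl)cc(-c2nn(-c3cccc(NC(=O)Nc4ccc(Cl)c(Cl)c4)c3)cc2-c2ccncc2)c1`, has not been measured in this assay. It differs from compound 2 by chloro in place of trifluoromethyl on an aromatic carbon. Compound 1 already carries a 3,4-dichlorophenyl urea on a related core and gives 102%, and compound 2 with its 4-chloro-3-(trifluoromethyl)phenyl gives 100%, so no step beyond the scatter is expected in this assay.

Compound 3 is therefore expected to give 100%, with a range of 90% to 110%, a step from compound 2 to compound 3 of about no change at the digits printed from compound 2 to compound 3 (within the scatter).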

Compound 3, a percentage reported as activity, at one concentration (the size of the read-out at that concentration, not a potency): 100%
The estimate for compound 3 equals the measured number at the digits printed, and the stated range covers the measured number.
By their numbers in this assay, from the lowest: compounds 2, 3 and 1 (each within the scatter of the next).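

In this assay the change of trifluoromethyl to chloro on the urea aryl ring gives no change at the digits printed from compound 2 to compound 3 (within the scatter) in a direct comparison at this position, which compounds 1 and 2 could not provide, as they differ in more than one place. Methyl in place of hydrogen on the oxygen on the aromatic ring can now also be read on its own, and it gives a number 2 percentage points lower from compound 1 to compound 3 (within the scatter) at this single concentration. Neither change separates the compounds in this read-out, and no further data bear on the result.

From the compounds shown here alone, whether an amine or a carboxylic acid at this position on the urea aryl ring would read differently in this assay remains open. So does whether a longer chain on the oxygen would do so, and whether these compounds would separate at other concentrations.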